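A methoxy group added to compound 2

The compounds below may be only part of what the source reports. "The series", "measured", "known", "first", "only" and "open" are said of these compounds alone.

In a functional assay on HCT-8 cells (Homo sapiens) for antiproliferative activity, read by MTT assay, with a stated time of 48 h (a lower number here means a stronger inhibitor, a higher number a weaker inhibitor), compound 1 `CCNCC(=O)Nc1cc(OC)ccc1C(=O)c1cc(OC)c(OC)c(OC)c1` gives 1560 nM while compound 2 `C=C(c1cc(OC)c(OC)c(OC)c1)c1ccc(OC)c(O)c1NC(C)=O` gives 340 nM and so holds the lower of the two numbers. That gap lies beyond the usual scatter, which makes compound 2 the stronger inhibitor of this pair and the natural starting point for the next comparison.

Compound 3 `C=C(c1cc(OC)c(OC)c(OC)c1)c1ccc(OC)c(O)c1NC(=O)COC` differs from compound 2 in one place only. The change is methoxy in place of hydrogen on a saturated chain carbon bound to a carbonyl carbon and it sits on a saturated chain carbon bound to a carbonyl carbon, so that acetamido becomes ((methoxymethyl)carbonyl)amino.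

Among the compounds with values here, no two measured compounds differ in this way, so the data give no direct guide to what this change does. The expectation therefore rests on the small size of the change and on the value of compound 2 at 340 nM as an anchor. The expected result is a slight shift toward weaker inhibition, a 1.5-fold higher number from compound 2 to compound 3 (0.17 log units; within the scatter) in this assay (a step not expected to clear the scatter). The estimate for compound 3 is 500 nM (expected range from 130 nM to 1800 nM).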

Compound 3, half-maximal inhibitory concentration: 280 nM
The estimate for compound 3 lay 1.8-fold (0.25 log units) above the measured number; the range from low to high includes it.
By their numbers in this assay, from the lowest: compounds 3 and 2 (each within the scatter of the next); then compound 1.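

In this assay, placing methoxy in place of hydrogen on a saturated chain carbon bound to a carbonyl carbon, which turns acetamido into ((methoxymethyl)carbonyl)amino, gives a 1.2-fold lower number from compound 2 to compound 3 (0.08 log units; within the scatter) and so leaves compounds 2 and 3 indistinguishable in this read-out. Within the data shown here, this is the first direct look at this position, and it shows that the chain can carry a methoxy group, with its 2 heavy atoms and 1 hydrogen-bond acceptor, without a change in the number that clears the usual scatter of repeated measurements. The pair shows what happens to the number but not what lies behind it, as no other measurement here bears on this result.

One substitution at one carbon cannot show how much more this chain would tolerate, or whether the outcome depends on the oxygen or simply on the added length. Replacing the methoxy on this saturated chain carbon with ethoxy, a longer chain, or placing a carboxylic acid there would test how far the same result holds.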